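Series notes: amide replacement of the thiadiazole on compound 1

This account rests on a few compounds, and the source may have more. Where it says the series, first, only, none or still open, it means among the compounds named here.

Measured compounds:
compound 1 `OCc1nnc(-c2ccc(N3CCC(Oc4ccccc4C(F)(F)F)CC3)nn2)s1`, 3.2 nM
compound 2 `CCc1ccccc1OC1CCN(c2ccc(-n3ccnc3)nn2)CC1`, 4 nM
compound 3 `c1cc2c(c(OC3CCN(c4ccc(-n5ccnc5)nn4)CC3)c1)CCC2`, 10 nM

In an assay on microsomes from liver for inhibition of acyl-CoA desaturase 1 (Rattus norvegicus) (on this read-out lower numbers stand for stronger inhibition and higher numbers for weaker inhibition), compound 1 gives the lowest of the three numbers. Compound 2 lies within the scatter of it, while compound 3 sits beyond the scatter above compound 1. Within the data shown here, the only measured single-point step, a 2.5-fold higher number from compound 2 to compound 3 (0.40 log units; beyond the scatter), concerns the aryl group on the ether oxygen and leaves the other end of the core untouched.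

Compound 4 `O=C(NCCC1CC1)c1ccc(N2CCC(Oc3ccccc3C(F)(F)F)CC2)nn1` is the unmeasured analogue of compound 1. The change is (2-cyclopropylethyl)carbamoyl in place of 5-(hydroxymethyl)-1,3,4-thiadiazol-2-yl on an aromatic carbon. Among the measured compounds shown here, no measured pair in the set varies this position, so the step of a 2.5-fold higher number from compound 2 to compound 3 (0.40 log units; beyond the scatter) does not bear on it and there is no direct precedent for its direction or size. Compound 1 is close to the floor of the measured range, which leaves more room for the number to rise than to fall; the step of a 2.5-fold higher number from compound 1 to compound 4 (0.40 log units; beyond the scatter) is therefore expected to be modest and upward, with a wide range. For compound 4 the estimate in this assay is 8 nM, spanning 2 nM to 40 nM.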

Compound 4, half-maximal inhibitory concentration: 14 nM
The estimate for compound 4 lay 1.8-fold (0.24 log units) below the measured number, and the stated range covers the measured number.
By their numbers in this assay, from the lowest: compounds 1 and 2 (each within the scatter of the next); then compounds 3 and 4 (each within the scatter of the next).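

In this assay, among these compounds, replacing 5-(hydroxymethyl)-1,3,4-thiadiazol-2-yl with (2-cyclopropylethyl)carbamoyl gives a 4.4-fold higher number from compound 1 to compound 4 (0.64 log units; beyond the scatter), the only step at this place, which shows that the group on this aromatic carbon moves the number beyond the scatter. The change is still modest in size, even though the entering group has no aromatic ring and has fewer hydrogen-bond acceptors, with the same count of donors. No measurement here accounts for the rise.

This single step changes the ring, the acceptor count and the chain together, so the shown compounds do not tell which of these goes with the higher number. Also open, on these data alone, is how a methyl amide, a longer chain on the amide nitrogen, or a carboxylic acid at this place would read in this assay.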